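The source may report more compounds than this note shows. Statements on the series, on what has been measured and on what is new or still open speak of the compounds shown alone.

In a functional assay for inhibition, with Homo sapiens as the target (on this read-out higher numbers stand for weaker inhibition and lower numbers for stronger inhibition), compound 1 `Cc1nc(C)n2c(S)nncc12` gives > 48000 nM, which is a limit of the assay and not a number. Compound 2 `Cc1ncn2c(O)nncc12` likewise gives only a limit, > 48000 nM. Compound 3 `CSc1nncc2c(C)nc(C)n12` also gives only a limit, > 48000 nM. Compound 3 thus stands where every value shown stands, at the limit of > 48000 nM in this assay, at which 3 of the 3 values shown sit. The step from compound 3 to compound 4 `CSc1nncc2c(C)ncn12` is hydrogen in place of methyl on an aromatic carbon. For the measured compounds named here, the only measured step that bears on it, a step that the two limits leave unreadable from compound 1 to compound 3, is framed by two limits and shows no readable size, so no direction can be drawn from it. Compound 4 is therefore expected to remain at the limit, with an estimate of 60000 nM and a range of 20000 nM to 200000 nM. The expected step is a step that the limit leaves unreadable from compound 3 to compound 4.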

Compound 4, half-maximal inhibitory concentration: > 48000 nM
Compound 4: only a limit was reported; the forecaster's own chance of this, stated with the estimate: 85%; the middle value is on the limit's open side.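

Compound 4 also gives only a limit, so the steps to it from compound 2 and from compound 3 cannot be read, because both ends of each are limits: the limit of > 48000 nM in this assay, at which 4 of the 4 values shown sit.

The compounds shown leave open what structure would give a readable value in this assay.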